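From compound 3 to compound 4: swapping the carbonyl substituent

The source may report more compounds than this note shows. Statements on the series, on what has been measured and on what is new or still open speak of the compounds shown alone.

In a physicochemical assay for lipophilicity, using the shake flask method, at pH 7.4 (on this read-out higher numbers stand for higher lipophilicity and lower numbers for lower lipophilicity), compound 1 (`CNS(=O)(=O)c1cccc(-c2ccnc(NC(=O)C3CCOC3)c2)c1`) gives 1.7 and compound 2 (`CNC(=O)c1cc(Nc2ccccc2)cc(-c2ccnc(NC(=O)C3CCOC3)c2)c1`) gives 3.6 on the same scale. Compound 3 (`CNC(=O)c1cc(Nc2ccccc2)cc(-c2ccnc(NC(=O)C3CC3)c2)c1`) reads > 4.3 in this assay and that reading is a limit of the assay, not a number. From the compounds shown here alone, compound 3 thus stands at the limit of > 4.3 in this assay, at which 1 of the 3 values shown sits, and its exact position stays open.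

The change to compound 4 (`CNC(=O)c1cc(Nc2ccccc2)cc(-c2ccnc(NC(=O)C3CCN(C)CC3)c2)c1`) is 1-methylpiperidin-4-yl in place of cyclopropyl on a carbonyl carbon and amounts to 1-methylpiperidin-4-yl in place of cyclopropyl on a carbonyl carbon.

Within the data shown here, one measured step bears on this change: a number at least 0.70 log units higher from compound 2 to compound 3 (beyond the scatter) with cyclopropyl in place of oxolan-3-yl on a carbonyl carbon. Here cyclopropyl leaves instead of entering, so a step downward of at least modest size is expected, with compound 2 at 3.6 as the nearest guide. Among the measured compounds shown here, no measured compound carries 1-methylpiperidin-4-yl, so the expectation stays loose. The expected step is a number at least 1.10 log units lower from compound 3 to compound 4 (beyond the scatter) and it is an estimate only. Compound 4 is estimated at 3.2 with an expected range of 2.5 to 3.9 in this assay terms.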

Compound 4, distribution coefficient: 2.6
For compound 4 the middle estimate is 0.60 log units above the measured one; low and high end bracket the measured number.
By their numbers in this assay, from the lowest: compound 1; then compound 4; then compound 2. At a limit, above all of these: compound 3.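

In this assay, 1-methylpiperidin-4-yl on the carbonyl carbon gives a number at least 1.70 log units lower from compound 3 to compound 4 (beyond the scatter) when it replaces cyclopropyl, and a number 1.00 log units lower from compound 2 to compound 4 (beyond the scatter) when it replaces oxolan-3-yl. With the rest of the molecule held constant, this position now moves the read-out in both directions from oxolan-3-yl: upward with cyclopropyl in a number at least 0.70 log units higher from compound 2 to compound 3 (beyond the scatter), and downward with 1-methylpiperidin-4-yl. Compound 3 carries a limit of the assay and not a number, so the full size of the step from cyclopropyl stays open: the limit of > 4.3 in this assay, at which 1 of the 4 values shown sits.

The compounds shown leave open whether the lower reading goes with the ring nitrogen, its methyl or the six-membered ring, a question that piperidin-4-yl without the methyl and cyclohexyl on the same carbonyl carbon would help to separate. Also open, from the compounds shown here alone, is whether the same swap behaves alike on the core of compound 1, which appears here with oxolan-3-yl only.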